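The source may hold more compounds than are shown below. What is called first, only, known or untested is meant among the compounds shown, and "the series" means these compounds.

Working notes on the series. All compounds are read in a functional assay on MKN-45 cells (Homo sapiens) for cytotoxicity, read by MTT assay, with a stated time of 72 h; a higher number here means a weaker inhibitor, a lower number a stronger inhibitor. Compound 1 `COc1ccc(-c2cc(C(=O)Nc3ccc(Oc4ccnc5cc(OCCCN6CCC(C)CC6)c(OC)cc45)c(F)c3)c3ccccc3n2)cc1` gives 320 nM in this assay. Compound 2 `COc1cc2c(Oc3ccc(NC(=O)c4cc(-c5ccc(C)cc5)nc5ccccc45)cc3F)ccnc2cc1OCCCN1CCC(C)CC1` gives 770 nM. Compound 3 `COc1cc2c(Oc3ccc(NC(=O)c4cc(-c5ccc(C)cc5)nc5ccc(F)cc45)cc3F)ccnc2cc1OCCCN1CCCCC1` gives 170 nM, the lowest of the three numbers; the gap to compound 1 lies within the scatter, the gap to compound 2 beyond it. Compound 4 `COc1ccc(-c2cc(C(=O)Nc3ccc(Oc4ccnc5cc(OCCCN6CCCCC6)c(OC)cc45)c(F)c3)c3cc(F)ccc3n2)cc1` has not been measured yet.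

Compound 1 differs from compound 2 by methoxy in place of methyl on an aromatic carbon. That change produced a 2.4-fold lower number from compound 2 to compound 1 (0.38 log units; beyond the scatter). Compound 4 differs from compound 3 by methoxy in place of methyl on an aromatic carbon, the same change at the same place. How the core of compound 3 differs from the core of compound 2 is not broken down here. The expectation for compound 4 therefore rests on one matched pair only and is held loosely.

In this assay compound 4 is expected to show a 2.4-fold lower number from compound 3 to compound 4 (0.39 log units; beyond the scatter), about the size seen in the earlier pair. Compound 4 is accordingly estimated at 70 nM, with a range from 35 nM to 140 nM.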

Compound 4, half-maximal inhibitory concentration: 260 nM
Beside the measured number, compound 4's estimate is 3.7-fold (0.57 log units) below it; measured number above the stated range.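

In this assay, going from 4-methylphenyl to 4-methoxyphenyl gives a 1.5-fold higher number from compound 3 to compound 4 (0.18 log units; within the scatter), so on this core the change cannot be told apart from repeat scatter. The same change therefore does not carry over at the same size from one core to the other: the same change on two cores in this assay, a 2.4-fold lower number (0.38 log units; beyond the scatter) from compound 2 to compound 1 and a 1.5-fold higher number (0.18 log units; within the scatter) from compound 3 to compound 4, 3.7-fold (0.57 log units) apart, beyond the scatter of two such steps. Among these compounds, this shows that, for these two pairs, the step cannot be transferred from one core to the other as a fixed increment; it does not show which feature of the cores sets the difference, how the two cores differ is not broken down here, and with only one pair on each core no general rule for the series follows.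

From the compounds shown here alone, it remains open whether other groups in the same place, such as 4-chlorophenyl or a phenyl carrying an amine, would also give steps that differ between these two cores. Also open, going by these compounds, is whether the methyl to methoxy step would hold on further cores, where a third pair could show which of the two steps is the more typical.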